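This account rests on a few compounds, and the source may have more. Where it says the series, first, only, none or still open, it means among the compounds named here.

Working notes on the series.

Three compounds share one core and have been run in an in vitro ADME assay on microsomes from liver (Homo sapiens) for pharmacokinetics, read by LC-MS, with a stated time of 10 min, tested at 1 uM; on this read-out higher numbers stand for fast clearance and lower numbers for slow clearance. Compound 1 `Cc1ccc(NC(=O)[C@H]2CN(C)C[C@@H]2c2ccc(/C=C/C(=O)Nc3ccccc3N)cc2)cc1` gives 15 mL/min/kg in this assay. Compound 2 `COc1ccc(NC(=O)[C@H]2CN(C)C[C@@H]2c2ccc(/C=C/C(=O)Nc3ccccc3N)cc2)cc1` gives 14 mL/min/kg in this assay. Compound 3 `Cc1cccc(NC(=O)[C@H]2CN(C)C[C@@H]2c2ccc(/C=C/C(=O)Nc3ccccc3N)cc2)c1` gives 14 mL/min/kg in this assay. Among the compounds with values here, the three numbers sit close together: a 1.1-fold lower number from compound 1 to compound 2 (0.03 log units; within the scatter), a 1.1-fold lower number from compound 1 to compound 3 (0.03 log units; within the scatter) and no change at the digits printed from compound 2 to compound 3 (within the scatter), so no compound in this set can be set apart from the others.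

Compound 4 `COc1cccc(NC(=O)[C@H]2CN(C)C[C@@H]2c2ccc(/C=C/C(=O)Nc3ccccc3N)cc2)c1` has not yet been measured in this assay. It stands to compound 3 as compound 2 stands to compound 1. The change from compound 1 to compound 2 is methoxy in place of methyl on an aromatic carbon, and in this assay it made a 1.1-fold lower number from compound 1 to compound 2 (0.03 log units; within the scatter). The change from compound 3 to compound 4 is methoxy in place of methyl on an aromatic carbon. The two cores differ as 3-methylphenyl in place of 4-methylphenyl on an amide-type nitrogen. The places are not the same word for word: in the measured pair the group sits para to a large group, in the new pair it sits meta to a large group, so the second change is the same kind of change, not the same one.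

On the strength of the measured pair, where compound 1 to compound 2 moved only within the scatter a 1.1-fold lower number from compound 1 to compound 2 (0.03 log units; within the scatter), the step from compound 3 to compound 4 is expected to be a 1.1-fold lower number from compound 3 to compound 4 (0.03 log units; within the scatter). Compound 4 is therefore estimated at 13 mL/min/kg in this assay, with a range from 8 mL/min/kg to 22 mL/min/kg.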

Compound 4, clearance: 14 mL/min/kg
Compound 4: middle estimate off by 1.1-fold (0.03 log units), on the low side; the range from low to high includes it.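

In this assay the new readings are no change at the digits printed from compound 3 to compound 4 (within the scatter), no change at the digits printed from compound 2 to compound 4 (within the scatter) and a 1.1-fold lower number from compound 1 to compound 4 (0.03 log units; within the scatter). Methoxy in place of methyl on an aromatic carbon reads alike on the two cores: the same change on two cores in this assay, a 1.1-fold lower number (0.03 log units; within the scatter) from compound 1 to compound 2 and no change at the digits printed (within the scatter) from compound 3 to compound 4, 1.1-fold (0.03 log units) apart, within the scatter of two such steps This shows that the change carries between the 4-substituted and 3-substituted phenyl amides without a step that can be told from the scatter, but with every step this small it does not show that a real effect transfers from one core to the other, and it gives no ranking among the four compounds.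

The compounds shown leave open whether a group further removed from methyl and methoxy, such as an amine, a carboxylic acid or a longer alkoxy chain, would produce a step beyond the scatter in this assay when placed on the same phenyl ring. They also leave open whether any such step would carry between the 3-substituted and 4-substituted cores, which can be read only from a change that moves the number on at least one of them.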